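The compounds below may be only part of what the source reports. "The series", "measured", "known", "first", "only" and "open" are said of these compounds alone.

Compound 1 `COc1ccc(-c2[nH]c3ccc(C)cc3c2C2=C(Br)C(=O)NC2=O)cc1`: 2.85 in a physicochemical assay for lipophilicity; a lower number here means a more polar compound, a higher number a more lipophilic compound.
Compound 2 `CCCCCCc1ccc2[nH]c(-c3ccc(OC)cc3)c(C3=C(Br)C(=O)NC3=O)c2c1`: "not determined" (no result reported) in this assay.
Compound 3 `CCCCCCc1ccc2[nH]c(-c3cccc(OC)c3)c(C3=C(Br)C(=O)NC3=O)c2c1`: to be measured in this assay.

Compound 2 stands on no single number in this assay, so its position cannot be placed against compound 1. Compound 3 differs from compound 2 by 3-methoxyphenyl in place of 4-methoxyphenyl on an aromatic carbon. For the measured compounds named here, no step between measured compounds is available for this change, and no shift beyond the usual scatter of this assay is expected in either direction between compound 2 and compound 3. Going by the values given here, the only measured anchor remains compound 1 at 2.85. For compound 3 the expected value in this assay is 4.6, with a range from 3.6 to 5.6.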

Compound 3, partition coefficient: 4.26
For compound 3 the middle estimate is 0.34 log units above the measured one; the range from low to high includes it.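

For the compounds shown here, compound 2 has no single number in this assay and compound 3 has 4.26; no step between them can be read. The compounds shown leave open what 3-methoxyphenyl in place of 4-methoxyphenyl does to this read-out. No further evidence bears on the result.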